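Sulfonyl Heteroaryl Swaps in a Glycine Transporter Series

The compounds below may be only part of what the source reports. "The series", "measured", "known", "first", "only" and "open" are said of these compounds alone.

This account follows three compounds that share one core and differ only in the aromatic ring on the sulfonyl sulfur. In an assay on JAR cells for inhibition of sodium- and chloride-dependent glycine transporter 1 (Homo sapiens), read by scintillation counting, with a stated time of 3 h (on this read-out higher numbers stand for weaker inhibition and lower numbers for stronger inhibition), compound 1 `Cn1cnnc1S(=O)(=O)N1CCC(CNC(=O)c2ccc(Cl)cc2Cl)(CC2CC2)CC1` gives 124 nM. Compound 2 `Cn1cc(S(=O)(=O)N2CCC(CNC(=O)c3ccc(Cl)cc3Cl)(CC3CC3)CC2)nn1` gives 32 nM, and compound 3 `Cn1cc(S(=O)(=O)N2CCC(CNC(=O)c3ccc(Cl)cc3Cl)(CC3CC3)CC2)cn1` gives 10.4 nM. Compound 3 thus holds the lowest number of the three: the steps to it read a 12-fold lower number from compound 1 to compound 3 (1.08 log units; beyond the scatter) and a 3.1-fold lower number from compound 2 to compound 3 (0.49 log units; beyond the scatter), both beyond the scatter, so it counts as the strongest inhibitor on these numbers.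

Compound 4 `Cn1ncnc1S(=O)(=O)N1CCC(CNC(=O)c2ccc(Cl)cc2Cl)(CC2CC2)CC1` continues the same theme: 1-methyl-1H-1,2,4-triazol-5-yl in place of 1-methyl-1H-pyrazol-4-yl on a sulfonyl sulfur. The bearing steps are those in which the ring on the sulfonyl sulfur gains hetero atoms. Moving from a ring with two hetero atoms to one with three read a 3.1-fold lower number from compound 2 to compound 3 (0.49 log units; beyond the scatter) in reverse, and the other three-hetero-atom ring stood further off still, at a 12-fold lower number from compound 1 to compound 3 (1.08 log units; beyond the scatter) in reverse. Both point toward a higher number for compound 4. The expected step is therefore a 5.3-fold higher number from compound 3 to compound 4 (0.72 log units; beyond the scatter), a modest weakening beyond the scatter. Compound 4 is estimated at 55 nM, within a range of 18 nM to 170 nM.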

Compound 4, half-maximal inhibitory concentration: 314 nM
Beside the measured number, compound 4's estimate is 5.7-fold (0.76 log units) below it; measured number outside the range, above it.
By their numbers in this assay, from the lowest: compound 3; then compound 2; then compound 1; then compound 4.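

The change to 1-methyl-1H-1,2,4-triazol-5-yl on the sulfonyl sulfur gives a 30-fold higher number from compound 3 to compound 4 (1.48 log units; beyond the scatter), the largest step among these compounds, and leaves compound 4 as the weakest inhibitor of the four. The three triazoles also separate clearly from one another, with a 9.8-fold higher number from compound 2 to compound 4 (0.99 log units; beyond the scatter) and a 2.5-fold higher number from compound 1 to compound 4 (0.40 log units; beyond the scatter), so across these compounds the ring type alone does not fix the number, and the way the ring atoms and the methyl group are arranged also counts. Nothing shown here offers a measured reason for these differences.

From the compounds shown here alone, it remains open whether a phenyl or a thiophene ring on the sulfonyl sulfur would give a number lower or higher than that of compound 3. Going by these compounds, it is also open whether this order of rings would hold on a different core.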